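Amide Swap on a Shared Piperidine Core

The source may report more compounds than this note shows. Statements on the series, on what has been measured and on what is new or still open speak of the compounds shown alone.

Measured compounds:
- compound 1 `CN(Cc1ccccc1)C(=O)C1CCN(C(=O)c2ccc(S(C)(=O)=O)c([N+](=O)[O-])c2)CC1`: > 60000 nM
- compound 2 `CN1CCN(C(=O)C2CCN(C(=O)c3ccc(S(C)(=O)=O)c([N+](=O)[O-])c3)CC2)CC1`: > 60000 nM
- compound 3 `CC(C)N(C(=O)C1CCN(C(=O)c2ccc(S(C)(=O)=O)c([N+](=O)[O-])c2)CC1)C(C)C`: > 60000 nM

Three amides built on one shared core have been tested in an assay on isolated protein for inhibition of vitamin D3 receptor (Homo sapiens), read by fluorescence polarization; on this read-out higher numbers stand for weaker inhibition and lower numbers for stronger inhibition. Compound 1 reaches only the limit of the assay, > 60000 nM. Compound 2 likewise gives only a limit, > 60000 nM. Compound 3 stands at the same limit, > 60000 nM, so no number is known for it, only that its inhibition is weaker than the assay can read. All three values sit together at one ceiling (the limit of > 60000 nM in this assay, at which 3 of the 3 values shown sit), and the steps between them, a step that the two limits leave unreadable from compound 1 to compound 2, a step that the two limits leave unreadable from compound 1 to compound 3 and a step that the two limits leave unreadable from compound 2 to compound 3, cannot be sized.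

Compound 4 `CS(=O)(=O)c1ccc(C(=O)N2CCC(C(=O)N3CCc4ccccc4C3)CC2)cc1[N+](=O)[O-]` is not yet measured. It differs from compound 3 in one place: 1,2,3,4-tetrahydroisoquinolin-2-yl in place of diisopropylamino on a carbonyl carbon. The two steps that arrive at compound 3 bear on this change, since each also swapped the group on this carbonyl carbon, yet both are unreadable, so they give no size for this assay. Compound 4 is therefore expected to show no readable change, with the step that the limit leaves unreadable from compound 3 to compound 4 most likely again hidden at the limit. For compound 4 the estimate in this assay is 80000 nM, ranging from 20000 nM to 300000 nM.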

Compound 4, half-maximal inhibitory concentration: > 60000 nM
Compound 4 was reported as a limit (the forecaster's own chance of this, stated with the estimate: 80%); the middle value lies beyond the limit too.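

In this assay, within the data shown here, no step among compound 1, compound 2, compound 3 and compound 4 can be read, because all four sit at one ceiling: the limit of > 60000 nM in this assay, at which 4 of the 4 values shown sit.

The compounds shown leave open whether any group on this carbonyl carbon of the shared core gives a readable inhibition, and how far each of the four lies beyond the limit.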